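Fluoro on the aryl ring of a bicyclic alkyne series

The compounds below may be only part of what the source reports. "The series", "measured", "known", "first", "only" and "open" are said of these compounds alone.

Compound 1 `O=C1NCCc2nc(C#Cc3cccc(F)c3)sc21` — 290 nM
Compound 2 `O=C1NCCc2nc(C#Cc3ccccc3F)sc21` — 1500 nM
Compound 3 `CN1CCc2nc(C#Cc3ccccc3)sc2C1` — 34 nM

In an assay on HEK293 cells for positive allosteric modulation of metabotropic glutamate receptor 5 (Homo sapiens), read by FLIPR, with a stated time of 1 h (on this read-out lower numbers stand for an effect already at smaller amounts and higher numbers for an effect only at larger amounts of compound), compound 3 gives 34 nM, the lowest of the three numbers; the gap to compound 1 and the larger gap to compound 2 both lie beyond the scatter. Compound 1 and compound 2 share a different core from compound 3, so neither forms a single-change pair with it. Compound 4 `CN1CCc2nc(C#Cc3cccc(F)c3)sc2C1` differs from compound 3 by fluoro in place of hydrogen on an aromatic carbon. Going by the values given here, no measured pair isolates this change on the core of compound 3, so the step in this assay is expected to be small, in either direction, and possibly within the scatter; the expectation is a step of a 1.2-fold higher number from compound 3 to compound 4 (0.07 log units; within the scatter). Compound 4 is estimated at 40 nM, in a range from 15 nM to 110 nM.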

Compound 4, half-maximal effective concentration: > 10000 nM
Compound 4 ended at the assay's limit; the forecaster's own chance of this, stated with the estimate: 2%; middle value at least 250-fold (2.39 log units) away from the limit.
By their numbers in this assay, from the lowest: compound 3; then compound 1; then compound 2. At a limit, above all of these: compound 4.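

On the core of compound 3, fluoro in place of hydrogen on an aromatic carbon, meta to a large group, is far from a neutral change: in this assay the result is an at least 290-fold higher number from compound 3 to compound 4 (2.46 log units; beyond the scatter). The value of compound 4 is a limit of the assay, not a number: the limit of > 10000 nM in this assay, at which 1 of the 4 values shown sits. Going by these compounds alone, compound 1 and compound 2 carry fluoro on a different core and form no single-change pair with compound 3, so this is the only reading of the change on this core.

From the compounds shown here alone, whether this step is specific to fluoro remains open; chloro or methyl at the same place would test that. Also open, going by these compounds, is whether the change acts alike on the core of compound 1.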